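This account rests on a few compounds, and the source may have more. Where it says the series, first, only, none or still open, it means among the compounds named here.

Three compounds share one core and were measured in an in vivo ADME assay on the whole organism (strain Mongrel) for pharmacokinetics, with Canis familiaris (Canis lupus familiaris) as the target; on this read-out lower numbers stand for slow clearance and higher numbers for fast clearance:

Compound 1, `COc1cncc(C(=O)NC2(C(=O)N[C@H](C)c3ccc(-n4nc(Cl)c5ccccc54)cc3F)CC2)c1`, gives 5.5 mL/min/kg.
Compound 2, `C[C@@H](NC(=O)C1(NC(=O)c2cncc(Br)c2)CC1)c1ccc(-n2nc(Cl)c3ccccc32)cc1F`, gives 3.8 mL/min/kg.
Compound 3, `Cc1cncc(C(=O)NC2(C(=O)N[C@H](C)c3ccc(-n4nc(Cl)c5ccccc54)cc3F)CC2)c1`, gives 4.3 mL/min/kg.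

Compound 1 holds the highest of the three numbers, yet a 1.3-fold lower number from compound 1 to compound 3 (0.11 log units; within the scatter) and a 1.4-fold lower number from compound 1 to compound 2 (0.16 log units; within the scatter) both sit within the scatter, so the three values are indistinguishable on this read-out. Likewise a 1.1-fold higher number from compound 2 to compound 3 (0.05 log units; within the scatter) shows no movement beyond the noise.

Compound 4, `Cc1nnsc1C(=O)NC1(C(=O)N[C@H](C)c2ccc(-n3nc(Cl)c4ccccc43)cc2F)CC1`, has not been measured. It differs from compound 1 by 4-methyl-1,2,3-thiadiazol-5-yl in place of 5-methoxypyridin-3-yl on a carbonyl carbon. The measured steps all concern a substituent on the six-membered aromatic ring of compound 1, swapping methoxy for bromo or methyl, and each stayed within the scatter. Within the data shown here, none of them replaces the ring itself, so there is no direct precedent for the exchange in compound 4; the only guidance is that the measured changes in this region left this assay unmoved.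

He therefore expects for compound 4 no step beyond the scatter from compound 1, with a 1.1-fold lower number from compound 1 to compound 4 (0.04 log units; within the scatter) as the anticipated change. The estimate for compound 4 is 5 mL/min/kg, between 2.5 mL/min/kg and 10 mL/min/kg.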

Compound 4, clearance: 9.6 mL/min/kg
Compound 4: middle estimate off by 1.9-fold (0.28 log units), on the low side, and the stated range covers the measured number.
By their numbers in this assay, from the lowest: compounds 2, 3, 1 and 4 (each within the scatter of the next, the first and the last beyond it).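

In this assay, among these compounds, exchanging the whole ring on the carbonyl carbon is the first change at this position to move a number beyond the scatter: 4-methyl-1,2,3-thiadiazol-5-yl gives a 2.2-fold higher number from compound 3 to compound 4 (0.35 log units; beyond the scatter) in place of 5-methylpyridin-3-yl and a 2.5-fold higher number from compound 2 to compound 4 (0.40 log units; beyond the scatter) in place of 5-bromopyridin-3-yl, both modest, whereas the substituent swaps on the six-membered aromatic ring moved nothing beyond it. The same exchange made on the 5-methoxypyridin-3-yl group gives a 1.7-fold higher number from compound 1 to compound 4 (0.24 log units; within the scatter), so the separation appears against only two of the three partners, and compound 1 cannot be told apart from compound 2 or compound 4. No measurement shown accounts for the rise.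

Among the compounds shown here, it remains open whether the step belongs to the five-membered aromatic ring as such or to its methyl group and hetero atoms, as only one such ring appears here. Also open, from the compounds shown here alone, is how a plain phenyl or thiazole ring on the carbonyl carbon, or an amine, a carboxylic acid or a longer chain on the six-membered aromatic ring, would stand in this assay.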